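Aryl swap on the shared core: compound 2 to compound 3

A few compounds are considered here, and "the series" means these few. Any claim that something is new, unique, unknown or untested is made for them only; others in the source may bear on it.

In a functional assay on U-87MG ATCC cells for antiproliferative activity against U-87 MG (Homo sapiens), read by MTT assay, with a stated time of 48 h, tested at 50 uM (a lower number here means a stronger effect, a higher number a weaker effect of the compound at the concentration tested), compound 1 `COc1ccc(-c2nc(C)c(C(=O)CSc3nc(N)c(C#N)c(-c4ccccc4)n3)s2)cc1` gives 16.5%. Compound 2 `COc1ccc(-c2nc(C)c(C(=O)CSc3nc(-c4ccc(Cl)cc4)c(C#N)c(=O)[nH]3)s2)cc1` stands highest of the two numbers shown; in this assay compound 2 gives 48%, a number beyond the scatter away from compound 1. Within the data shown here, the two measured compounds differ in more than one place, so no single-change step between measured compounds is available, and nothing measured so far isolates the effect of the aryl group alone.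

Compound 3 `COc1ccc(-c2nc(C)c(C(=O)CSc3nc(-c4cccc(OC)c4)c(C#N)c(=O)[nH]3)s2)cc1` has not yet been measured. It differs from compound 2 by 3-methoxyphenyl in place of 4-chlorophenyl on an aromatic carbon. Among the measured compounds shown here, no measured pair shows what such a change does to the read-out, so the expectation rests on compound 2 alone. The step of a number 2 percentage points higher from compound 2 to compound 3 (within the scatter) is expected to be small, none beyond the scatter. Compound 3 is estimated at 50% in this assay, with a range from 30% to 70%.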

Compound 3, a percentage reported as activity, at one concentration (the size of the read-out at that concentration, not a potency): 43.2%
Estimate against measurement, compound 3: 6.8 percentage points above; measured number inside the range.
By their numbers in this assay, from the lowest: compound 1; then compounds 3 and 2 (each within the scatter of the next).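

In this assay, the series now has its first single-change step, a number 4.8 percentage points lower from compound 2 to compound 3 (within the scatter), and it gives no separation between 3-methoxyphenyl and 4-chlorophenyl on this aromatic carbon, ortho to a cyano group. At this position, one aryl group can therefore replace the other with a read-out that stays within the scatter, even though the substituent and its place on the aryl ring both differ. Nothing measured on these compounds bears on this result.

Among these compounds, the step cannot separate the swap of chlorine for methoxy from the shift in its place on the aryl ring, and no single-change step connects compound 1 to compound 2 or compound 3. Still open, as far as these compounds go, is how this position responds to an unsubstituted phenyl, a pyridine ring, a morpholine amine or a short alkyl chain such as ethyl.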